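This account rests on a few compounds, and the source may have more. Where it says the series, first, only, none or still open, it means among the compounds named here.

Of the compounds shown here, three have so far been measured in an assay on T-REx-293 cells for inhibition of potassium channel subfamily T member 1 (Homo sapiens), read by patch clamp; on this read-out higher numbers stand for weaker inhibition and lower numbers for stronger inhibition. Compound 1 `Cc1cccc(-c2nc(C(C)NC(=O)c3cc(C(F)(F)F)nn3C)no2)c1` gives 977 nM in this assay, compound 2 `C[C@H](NC(=O)c1cc(C(F)(F)F)nn1C)c1nc(-c2cccc(F)c2)no1` gives 136 nM and compound 3 `C[C@@H](c1nc(-c2cccc(F)c2)no1)N(C)C(=O)c1cc(C(F)(F)F)nn1C` gives 6490 nM. Compound 2 thus stands lowest of the three numbers; compound 1 is nearest to it and compound 3 furthest. Within the data shown here, the only step between compounds that differ in one place is a 48-fold higher number from compound 2 to compound 3 (1.68 log units; beyond the scatter), a methyl in place of hydrogen on an amide-type nitrogen. Compound 4 `C[C@H](NC(=O)c1cc(C(F)(F)F)nn1C)c1nc(-c2ccnc(N(C)C)c2)no1` keeps the amide hydrogen of compound 2 and differs from it elsewhere: 2-(dimethylamino)pyridin-4-yl in place of 3-fluorophenyl on an aromatic carbon. Among the measured compounds shown here, no measured step touches this aromatic carbon, so the amide step offers no guide to the size or direction of this one; compound 1 and compound 2 differ in more than one place, and only their two values can be set side by side. Because compound 2 gives 136 nM and nothing measured bears on the ring exchange, compound 4 is estimated at 400 nM, in a range from 80 nM to 2500 nM. The expected step of a 2.9-fold higher number from compound 2 to compound 4 (0.47 log units; beyond the scatter) is uncertain in direction and may fall within the scatter.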

Compound 4, half-maximal inhibitory concentration: 454 nM
Estimate against measurement, compound 4: 1.1-fold (0.05 log units) below, within the range that was stated.
By their numbers in this assay, from the lowest: compound 2; then compound 4; then compound 1; then compound 3.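

In this assay, among these compounds, 2-(dimethylamino)pyridin-4-yl in place of 3-fluorophenyl on the aromatic carbon gives a 3.3-fold higher number from compound 2 to compound 4 (0.52 log units; beyond the scatter), the first measured single change at this position. The position therefore responds to the group it carries, yet this modest step leaves compound 4 with measurable inhibition despite the larger group and its added hydrogen-bond acceptors. The step is smaller than the large one at the amide nitrogen, a 48-fold higher number from compound 2 to compound 3 (1.68 log units; beyond the scatter). Nothing available explains the rise in the number from this ring exchange.

From the compounds shown here alone, the exchange alters the ring atoms and the substituent together, so the share of each remains unknown. An unsubstituted pyridin-4-yl group and a 3-(dimethylamino)phenyl group would separate the ring nitrogen from the dimethylamino group.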